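This account rests on a few compounds, and the source may have more. Where it says the series, first, only, none or still open, it means among the compounds named here.

Measured in a functional assay on U-373MG ATCC cells (Homo sapiens) for inhibition, read by MTT assay, with a stated time of 72 h; on this read-out higher numbers stand for weaker inhibition and lower numbers for stronger inhibition:
- Compound 1 `CC1(C)CC(NC(=O)Nc2cccc(Cl)c2)c2cc(Br)ccc2O1`: 69000 nM
- Compound 2 `CC1(C)CC(NC(=O)Nc2ccccc2Cl)c2cc(Br)ccc2O1`: 19000 nM

Of these two, compound 2 stands lower, at 19000 nM. The next compound to consider is compound 3 `CC1(C)CC(NC(=O)Nc2ccc(Cl)cc2)c2cc(Br)ccc2O1`, and the change is 4-chlorophenyl in place of 2-chlorophenyl on an amide-type nitrogen. In short, 4-chlorophenyl takes the place of 2-chlorophenyl on an amide-type nitrogen.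

For the measured compounds named here, the only measured step bearing on this change is a 3.6-fold lower number from compound 1 to compound 2 (0.56 log units; beyond the scatter). It is a modest step, and it shows that, in this pair, the number shifts when 2-chlorophenyl replaces 3-chlorophenyl. Going by the values given here, no measured compound yet carries 4-chlorophenyl, so this single step gives only a rough guide. Among the compounds with values here, a modest rise in the number is expected, no larger than that step. The expected change is a 1.7-fold higher number from compound 2 to compound 3 (0.23 log units; within the scatter). For compound 3 the estimated value is 32000 nM, with an expected range of 12000 nM to 80000 nM.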

Compound 3, half-maximal inhibitory concentration: 25000 nM
Beside the measured number, compound 3's estimate is 1.3-fold (0.11 log units) above it; the measured number falls inside the stated range.
By their numbers in this assay, from the lowest: compounds 2 and 3 (each within the scatter of the next); then compound 1.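

With the third chlorophenyl isomer in hand, the position of the chlorine can be compared across all three compounds in this assay. The 4-chlorophenyl and 2-chlorophenyl groups cannot be told apart on the amide-type nitrogen (a 1.3-fold higher number from compound 2 to compound 3 (0.12 log units; within the scatter)), whereas 4-chlorophenyl, like 2-chlorophenyl, stands clearly apart from 3-chlorophenyl (a 2.8-fold lower number from compound 1 to compound 3 (0.44 log units; beyond the scatter)), so compound 1 is the weakest of the three and the only one that differs clearly from the others. Nothing available explains why the 3-chlorophenyl group stands apart.

As far as these compounds go, whether this order would hold with fluorine, methoxy or an amine in place of the chlorine remains open. So does the effect of replacing the bromine on the shared core, or of replacing the phenyl ring with a longer chain.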